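This account rests on a few compounds, and the source may have more. Where it says the series, first, only, none or still open, it means among the compounds named here.

Compound 1 `O=C(Nc1ccc2c(c1)B(O)OC2)c1ccccc1C(F)(F)F`: 4400 nM
Compound 2 `O=C(Nc1ccc2c(c1)B(O)OC2)c1ccccc1`: > 100000 nM

Of the compounds shown here, two sharing one core have been measured in a functional assay on PBMC cells (Homo sapiens) for inhibition, read by HTRF, with stated times of 15 min and 24 h; on this read-out lower numbers stand for stronger inhibition and higher numbers for weaker inhibition. Among the measured compounds shown here, compound 1 gives 4400 nM in this assay, and this is the only number among the two values shown. Compound 2 reaches only the limit of this assay, > 100000 nM. For the measured compounds named here, the single measured step is an at least 22-fold higher number from compound 1 to compound 2 (1.35 log units; beyond the scatter), and its stated size rests on the limit (the limit of > 100000 nM in this assay, at which 1 of the 2 values shown sits).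

Compound 3 `O=C(Nc1ccc2c(c1)B(O)OC2)c1ccccc1Cl` has not yet been measured in this assay. It differs from compound 1 by chloro in place of trifluoromethyl on an aromatic carbon. The measured step from compound 1 to compound 2 bears on this change: taking the trifluoromethyl away altogether gave a large loss of inhibition. Chloro is neither hydrogen nor trifluoromethyl, so a step in the same direction, but smaller than the one to compound 2, is expected, namely a 3.4-fold higher number from compound 1 to compound 3 (0.53 log units; beyond the scatter). For compound 3 the estimate in this assay is 15000 nM, with a range from 4000 nM to 60000 nM, and there remains some chance that only a limit is reported.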

Compound 3, half-maximal inhibitory concentration: > 100000 nM
Compound 3: no number, only a limit; the forecaster's own chance of this, stated with the estimate: 25%; at least 6.6-fold (0.82 log units) between middle value and limit.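

Putting chloro in place of trifluoromethyl on this aromatic carbon, ortho to a large group, gave an at least 22-fold higher number from compound 1 to compound 3 (1.35 log units; beyond the scatter) in this assay, so having a halogen-bearing or halogen substituent at this place was not enough to keep a readable value. Compound 3 gives only a limit, > 100000 nM, and its step from compound 1 is therefore a minimum size rather than an exact one. Of the three compounds, only the one carrying trifluoromethyl gives a number, and the step between compound 2 and compound 3 cannot be read, so chloro cannot be told apart from hydrogen here: the limit of > 100000 nM in this assay, at which 2 of the 3 values shown sit.

The compounds shown leave open whether another group at this place, such as methyl, bromo, methoxy or trifluoromethoxy, would give a number in this assay, and so whether the effect seen is particular to trifluoromethyl. They also leave open whether trifluoromethyl would give a similar value on another carbon of the same ring, and how far compound 2 and compound 3 lie beyond the limit they share.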